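Swapping a sulfonyl for a benzoyl on a prostaglandin D2 antagonist

A few compounds are considered here, and "the series" means these few. Any claim that something is new, unique, unknown or untested is made for them only; others in the source may bear on it.

Measured compounds:
- compound 1 `Cc1c(Cc2cc(Br)ccc2S(=O)(=O)c2ccccc2)c2c(n1CC(=O)O)CCNC2=O`: 3.9 nM
- compound 2 `Cc1c(Cc2ccccc2S(=O)(=O)c2ccccc2F)c2c(n1CC(=O)O)CCNC2=O`: 3.6 nM
- compound 3 `Cc1c(Cc2ccc(S(=O)(=O)c3ccccc3)cc2)c2c(n1CC(=O)O)CCNC2=O`: 170 nM

In a functional assay on CHO.K1 cells for antagonist activity at prostaglandin D2 receptor 2 (Homo sapiens), read by GTPgammaS binding, with a stated time of 1 h (a higher number here means a weaker inhibitor, a lower number a stronger inhibitor), compound 2 gives 3.6 nM, the lowest of the three numbers. Compound 1 sits within the scatter of it, while compound 3 gives 170 nM, a gap well outside that scatter. Compound 4 `Cc1c(Cc2ccccc2C(=O)c2ccccc2)c2c(n1CC(=O)O)CCNC2=O` is not yet measured. Among the measured compounds shown here, it differs from compound 2 in one place: benzoyl in place of (2-fluorophenyl)sulfonyl on an aromatic carbon No measured pair shows this kind of exchange, so the size of the step is open. The step is estimated at a 4.2-fold higher number from compound 2 to compound 4 (0.62 log units; beyond the scatter), which would leave compound 4 a strong inhibitor still. Compound 4 is therefore estimated at 15 nM, with a range from 4 nM to 60 nM.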

Compound 4, half-maximal inhibitory concentration: 810 nM
Beside the measured number, compound 4's estimate is 54-fold (1.73 log units) below it, and the stated range ends below it.
By their numbers in this assay, from the lowest: compounds 2 and 1 (each within the scatter of the next); then compound 3; then compound 4.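

On an aromatic carbon ortho to a large group, benzoyl in place of (2-fluorophenyl)sulfonyl gives a 230-fold higher number from compound 2 to compound 4 (2.35 log units; beyond the scatter) in this assay. Both groups carry one six-membered aromatic ring of carbon only, so having such a ring in this place does not by itself keep the number low. What is attached here matters greatly.

As far as these compounds go, the exchange removes the sulfonyl and the fluorine together, so their shares of the step remain open. Also open, from the compounds shown here alone, is how a 2-fluorobenzoyl or a sulfonamide would fare here, and no measurement at hand accounts for the step.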